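Benzoxazolone Piperidines at Sigma-1: From Fluoro to Phenyl

A few compounds are considered here, and "the series" means these few. Any claim that something is new, unique, unknown or untested is made for them only; others in the source may bear on it.

Of the compounds shown here, three sharing one core have been measured in an assay on membranes from liver for displacement of a labelled ligand from Sigma non-opioid intracellular receptor 1 (Rattus norvegicus); on this read-out higher numbers stand for weaker inhibition and lower numbers for stronger inhibition. Compound 1 `O=c1oc2ccccc2n1CC1CCN(Cc2ccccc2)CC1` gives 3.6 nM. Compound 2 `O=c1oc2ccccc2n1CC1CCN(Cc2ccc(Cl)cc2)CC1` gives 0.1 nM, and compound 3 `O=c1oc2ccccc2n1CC1CCN(Cc2ccc(F)cc2)CC1` gives 3.9 nM. Compound 3 has the highest number of the three; its nearest neighbour is compound 1, within the scatter, and its furthest is compound 2, with a 39-fold higher number from compound 2 to compound 3 (1.59 log units; beyond the scatter). The two measured changes at the same aromatic carbon pull apart: a 1.1-fold higher number from compound 1 to compound 3 (0.03 log units; within the scatter) against a 36-fold lower number from compound 1 to compound 2 (1.56 log units; beyond the scatter).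

Compound 4 `O=c1oc2ccccc2n1CC1CCN(Cc2ccc(-c3ccccc3)cc2)CC1` carries phenyl in place of fluoro on an aromatic carbon. Going by the values given here, no measured step introduces a phenyl, so the bearing steps only show that this position tolerates substitution and that one substituent there gave a large drop in the number while another gave none. The step from compound 3 to compound 4 is therefore expected to be a 3.9-fold lower number from compound 3 to compound 4 (0.59 log units; beyond the scatter), with wide uncertainty. Compound 4 is estimated at 1 nM, in the range 0.1 nM to 10 nM in this assay.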

Compound 4, inhibition constant: 394 nM
Estimate against measurement, compound 4: 390-fold (2.60 log units) below; measured number above the stated range.
By their numbers in this assay, from the lowest: compound 2; then compounds 1 and 3 (each within the scatter of the next); then compound 4.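

In this assay, going by these compounds alone, this aromatic carbon had so far taken fluoro without a change beyond the scatter and chloro with a large drop in the number, but phenyl is the first group to move the number sharply the other way, with a 110-fold higher number from compound 1 to compound 4 (2.04 log units; beyond the scatter) and a 100-fold higher number from compound 3 to compound 4 (2.00 log units; beyond the scatter). The position therefore does not accept every substituent, and the span across the series is wide, with a 3900-fold higher number from compound 2 to compound 4 (3.60 log units; beyond the scatter) for a single exchange at one carbon. No measurement shown explains why phenyl behaves so differently from the halogens.

The compounds shown leave open whether a methyl, methoxy or bromo group at this carbon would follow chloro or phenyl. They also leave open whether a saturated cyclohexyl ring would give the same result as phenyl.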